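The source may report more compounds than this note shows. Statements on the series, on what has been measured and on what is new or still open speak of the compounds shown alone.

Compound 1 `c1cc([C@H]2CC[C@]3(CC2)OOC2(O3)C3CC4CC(C3)CC2C4)ccc1OCC1CCNCC1` is one of two compounds read in an ADME assay on the whole organism (strain FVB) for pharmacokinetics, with Mus musculus as the target, read by LC-MS, at a dose of 30 mg/kg by the oral route; a lower number here means less compound in the circulation, a higher number more compound in the circulation at the dose given; compound 1 gives 4040 ng.h/mL. The other, compound 2 `CC(C)(CN)Oc1ccc([C@H]2CC[C@]3(CC2)OOC2(O3)C3CC4CC(C3)CC2C4)cc1`, gives 4840 ng.h/mL in this assay, and the step of a 1.2-fold higher number from compound 1 to compound 2 (0.08 log units; within the scatter) leaves the two within the scatter of each other. Compound 3 `CC(C)(N)CCOc1ccc([C@H]2CC[C@]3(CC2)OOC2(O3)C3CC4CC(C3)CC2C4)cc1` is not yet measured; it differs from compound 1 by 2-amino-2-methylpropyl in place of piperidin-4-yl on a saturated chain carbon bound to an oxygen on an aromatic ring. Among the measured compounds shown here, the only step that bears on this is that from compound 1 to compound 2, where an open-chain amine also replaced the piperidine on the aryl ether, and that step stayed within the scatter. Compound 3 is therefore expected to show a 1.1-fold higher number from compound 1 to compound 3 (0.05 log units; within the scatter), with an estimated exposure of 4500 ng.h/mL, in the range 2200 ng.h/mL to 9000 ng.h/mL.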

Compound 3, area under the concentration-time curve: 12300 ng.h/mL
For compound 3 the middle estimate is 2.7-fold (0.44 log units) below the measured one, and the stated range ends below it.
By their numbers in this assay, from the lowest: compounds 1 and 2 (each within the scatter of the next); then compound 3.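

In this assay an open-chain amine on this oxygen can change the reading: 3-amino-3-methylbutyl in place of (piperidin-4-yl)methyl gives a 3.0-fold higher number from compound 1 to compound 3 (0.48 log units; beyond the scatter) whereas compound 2 stayed within the scatter of compound 1. Losing the piperidine ring therefore does not decide the outcome on its own, as 3-amino-3-methylbutyl in place of 1-(aminomethyl)-1-methylethyl gives a 2.5-fold higher number from compound 2 to compound 3 (0.41 log units; beyond the scatter) with no ring in either chain. Nothing shown here explains the higher exposure.

Still open, on these data alone, is whether the gain survives in a 3-aminopropyl chain without the two methyl groups, or in a longer chain carrying the same amine.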